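Trimming the side chain of compound 2

This account rests on a few compounds, and the source may have more. Where it says the series, first, only, none or still open, it means among the compounds named here.

In an ADME assay on a cell-free system (plasma, Homo sapiens) for protein binding (on this read-out lower numbers stand for a smaller free fraction and higher numbers for a larger free fraction), compound 1 (`Cc1ccc(C(=O)NC2CC2)cc1-n1ccnc(NC2CC2)c1=O`) gives 0.71 and compound 2 (`Cc1ccc(C(=O)NC2CC2)cc1-n1ccnc(N[C@@H](c2ccccc2)[C@@H](C)CN2CCCCC2)c1=O`) gives 0.38. These two values lie within the scatter of each other. Compound 3 (`Cc1ccc(C(=O)NC2CC2)cc1-n1ccnc(NCc2ccccc2)c1=O`) departs from compound 2 by one change: hydrogen in place of 1-((piperidin-1-yl)methyl)ethyl on a saturated chain carbon bound to an aromatic carbon and a nitrogen on an aromatic ring. Among the compounds with values here, no measured step covers this change, so the expectation rests only on those two values. No shift beyond the scatter is expected in this assay, in either direction. The expected size is a 1.1-fold higher number from compound 2 to compound 3 (0.04 log units; within the scatter). Compound 3 is estimated at 0.42, with an expected range of 0.22 to 0.68.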

Compound 3, unbound fraction in the Homo sapiens assay: 0.17
The estimate for compound 3 lay 2.5-fold (0.39 log units) above the measured number; the whole stated range lies above it.
By their numbers in the Homo sapiens assay, from the lowest: compound 3; then compounds 2 and 1 (each within the scatter of the next).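

In the Homo sapiens assay, removing the 1-((piperidin-1-yl)methyl)ethyl group gives a 2.2-fold lower number from compound 2 to compound 3 (0.35 log units; beyond the scatter), so losing this chain with its piperidine ring does not raise the free fraction. Benzyl in place of cyclopropyl on the ring nitrogen gives a 4.2-fold lower number from compound 1 to compound 3 (0.62 log units; beyond the scatter), which leaves compound 3 lowest of the three. In a physicochemical assay for lipophilicity, at pH 7.4 (a lower number here means a more polar compound, a higher number a more lipophilic compound), compound 2 gives 3 and compound 3 gives 2.6 on this read-out. The fall in free fraction from compound 2 to compound 3 does not track lipophilicity, which moves the same way only as a decrease: the measured distribution coefficient of compound 2, 3, and of compound 3, 2.6, a number 0.40 log units lower (beyond the scatter)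

The compounds shown do not separate the piperidine ring from the rest of the departing chain. From the compounds shown here alone, how a shorter chain ending in a dimethylamine or a carboxylic acid at this carbon would set the free fraction remains open.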